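The source may hold more compounds than are shown below. What is called first, only, known or untested is meant among the compounds shown, and "the series" means these compounds.

Compound 1 `CCn1cnc2ncnc(N)c21` gives > 100000 nM in an assay on CHO cells for displacement of a labelled ligand from adenosine receptor A3 (Homo sapiens) (a lower number here means a stronger inhibitor, a higher number a weaker inhibitor), a limit rather than a number.
Compound 2 `CC(C)n1cnc2ncnc(N)c21` gives > 100000 nM in this assay, again a limit.
Compound 3 `CC(C)Cn1cnc2ncnc(N)c21` gives > 100000 nM in this assay, also a limit.

Compound 3 therefore stands where every measured compound stands: at the limit of > 100000 nM in this assay, at which 3 of the 3 values shown sit. Within the data shown here, no compound has a number, so none can be ranked against another. The three measured steps are unreadable for the same reason: a step that the two limits leave unreadable from compound 1 to compound 2, a step that the two limits leave unreadable from compound 1 to compound 3 and a step that the two limits leave unreadable from compound 2 to compound 3 all run between limits. Among the measured compounds shown here, they show only that enlarging or branching the chain on the aromatic nitrogen brings no compound inside the measurable range.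

Compound 4 `Nc1ncnc2ncn(CCO)c12` differs from compound 3 by hydroxymethyl in place of isopropyl on a saturated chain carbon bound to an aromatic nitrogen. The measured steps bear on it only indirectly: they concern the size and branching of the chain, not a hydroxyl group, and none gives a readable size. No step beyond the scatter is expected in this assay in either direction, and the estimated step is a number no higher from compound 3 to compound 4 (the limit leaves the size open). For compound 4 the expected value is 100000 nM, between 30000 nM and 300000 nM, most likely reported again as a limit.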

Compound 4, inhibition constant: > 100000 nM
Compound 4: only a limit was reported; the forecaster's own chance of this, stated with the estimate: 80%; the middle value sits exactly at the limit.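

No new step can be read: compound 4, like compound 1, compound 2 and compound 3, gives only a limit, so none of its steps has a size. The compounds shown leave open whether any chain on the aromatic nitrogen gives a measurable value in this assay.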